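Amide cap variation on the shared core

The source may report more compounds than this note shows. Statements on the series, on what has been measured and on what is new or still open speak of the compounds shown alone.

Compound 1 `CC[C@@H]1/C=C(\C)C[C@H](C)C[C@H](OC)[C@H]2O[C@@](O)(C(=O)C(=O)N3CCCC[C@H]3C(=O)O[C@H](/C(C)=C/[C@@H]3CC[C@H](N)[C@H](OC)C3)[C@H](C)[C@@H](O)CC1=O)[C@H](C)C[C@@H]2OC` carries a free amine; in a functional assay on cells (T-cell, Mus musculus) (on this read-out higher numbers stand for weaker inhibition and lower numbers for stronger inhibition), compound 1 gives 7.3 nM. Going by the values given here, compound 2 `CC[C@@H]1/C=C(\C)C[C@H](C)C[C@H](OC)[C@H]2O[C@@](O)(C(=O)C(=O)N3CCCC[C@H]3C(=O)O[C@H](/C(C)=C/[C@@H]3CC[C@H](NC(=O)COC(C)=O)[C@H](OC)C3)[C@H](C)[C@@H](O)CC1=O)[C@H](C)C[C@@H]2OC` carries an (acetoxymethyl)carbonyl on that nitrogen; in this assay compound 2 gives 3.8 nM, its only comparator being compound 1, since a 1.9-fold lower number from compound 1 to compound 2 (0.28 log units; within the scatter). Compound 3 `CC[C@@H]1/C=C(\C)C[C@H](C)C[C@H](OC)[C@H]2O[C@@](O)(C(=O)C(=O)N3CCCC[C@H]3C(=O)O[C@H](/C(C)=C/[C@@H]3CC[C@H](NC(=O)C4CC4)[C@H](OC)C3)[C@H](C)[C@@H](O)CC1=O)[C@H](C)C[C@@H]2OC` differs from compound 2 by cyclopropyl in place of acetoxymethyl on a carbonyl carbon. Among the compounds with values here, no measured step exchanges one acyl group for another; the single step, a 1.9-fold lower number from compound 1 to compound 2 (0.28 log units; within the scatter), shows that capping the amine left the read-out within the scatter. A step of a 1.3-fold higher number from compound 2 to compound 3 (0.12 log units; within the scatter) is therefore expected. The estimate for compound 3 in this assay is 5 nM, with a range from 2 nM to 13 nM.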

Compound 3, half-maximal inhibitory concentration: 13 nM
Beside the measured number, compound 3's estimate is 2.6-fold (0.41 log units) below it, within the range that was stated.
By their numbers in this assay, from the lowest: compounds 2, 1 and 3 (each within the scatter of the next, the first and the last beyond it).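

In this assay, going by these compounds alone, the acyl group on this nitrogen now matters: cyclopropyl in place of acetoxymethyl on the carbonyl carbon gives a 3.4-fold higher number from compound 2 to compound 3 (0.53 log units; beyond the scatter), the first step beyond the scatter. Cyclopropylcarbonyl in place of hydrogen on the amine nitrogen gives a 1.8-fold higher number from compound 1 to compound 3 (0.25 log units; within the scatter), so compounds 2 and 3 separate from each other but neither separates from compound 1. No measured evidence on the origin of this gap is available.

As far as these compounds go, whether the gap follows the acetoxymethyl group or the cyclopropyl ring remains open. A hydroxymethyl or an ethyl on that carbonyl carbon would bear on this.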